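The compounds below may be only part of what the source reports. "The series", "measured", "known", "first", "only" and "open" are said of these compounds alone.

Measured in an ADME assay on the whole organism (Rattus norvegicus) for pharmacokinetics, at a dose of 0.5 mg/kg by the intravenous route; a higher number here means faster removal of the compound, a lower number slower removal:
- Compound 1 `CNC(=O)N(c1ccc(S(=O)(=O)Nc2ccon2)cc1)c1ccc(-c2ccc(Cl)c(C)c2)cc1OC`: 22.2 mL/min/kg
- Compound 2 `CNC(=O)N(c1ccc(S(=O)(=O)Nc2ccon2)cn1)c1cc(F)c(-c2ccc(F)c(OC(F)(F)F)c2)cc1OC`: 48.3 mL/min/kg

Of these two compounds, compound 2 has the higher number, and the gap down to compound 1 lies beyond the scatter. Compound 2 and compound 1 differ in more than one place, so their two values cannot be assigned to any single structural change.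

The next compound to be tested is compound 3 `CNC(=O)N(c1ccc(S(=O)(=O)Nc2cccnn2)cn1)c1cc(F)c(-c2ccc(F)c(OC(F)(F)F)c2)cc1OC`, which departs from compound 2 in one place: pyridazin-3-yl in place of 1,2-oxazol-3-yl on a sulfonamide nitrogen. It carries pyridazin-3-yl in place of 1,2-oxazol-3-yl on a sulfonamide nitrogen. Going by the values given here, no measured pair shows this exchange, and neither measured compound carries pyridazin-3-yl, so the data give no direct guide to its size or direction. The starting point for the expectation is therefore compound 2 at 48.3 mL/min/kg. The estimated change is a 1.3-fold lower number from compound 2 to compound 3 (0.10 log units; within the scatter) in this assay, a slightly slower removal that is expected to stay within the scatter. For compound 3 the estimated clearance is 38 mL/min/kg, with an expected range from 16 mL/min/kg to 80 mL/min/kg.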

Compound 3, clearance: 11.7 mL/min/kg
Compound 3: middle estimate off by 3.2-fold (0.51 log units), on the high side, and the stated range ends above it.
By their numbers in this assay, from the lowest: compounds 3 and 1 (each within the scatter of the next); then compound 2.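

Going by these compounds alone, the group on the sulfonamide nitrogen matters in this assay: with the rest of compound 2 unchanged, pyridazin-3-yl in place of 1,2-oxazol-3-yl gives a 4.1-fold lower number from compound 2 to compound 3 (0.62 log units; beyond the scatter), the only step here that can be read at a single place. The earlier pair differed in more than one place, so no difference could be tied to this position; this step now shows that a change here alone can move the read-out beyond the scatter, even though the five-membered and six-membered aromatic rings have the same counts of hetero atoms, hydrogen-bond donors and hydrogen-bond acceptors. No measurement among these compounds explains why removal is slower with pyridazin-3-yl.

From the compounds shown here alone, whether the same exchange would give a similar step on the core of compound 1 remains open, as this step has been read on one background only. Also open, going by these compounds, is where other groups on the sulfonamide nitrogen, such as pyrimidin-2-yl or a simple methyl, would fall in this assay.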